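The compounds below may be only part of what the source reports. "The series", "measured", "known", "first", "only" and "open" are said of these compounds alone.

Measured compounds and their values:
Compound 1, `CNC(=O)/C=C/c1ccncc1-c1ccc2cccnc2c1`, gives 82% in an assay on a protein complex for inhibition of CDK8/Cyclin C (Homo sapiens), with a stated time of 1 h, tested at 10 uM; on this read-out lower numbers stand for less inhibition and higher numbers for more inhibition at the one concentration tested (going by the name of the read-out).
Compound 2, `NNC(=O)COc1ccncc1-c1ccc2ccccc2c1`, gives 19% in this assay.
Compound 3, `NC(=O)/C=C/c1ccncc1Nc1ccc(F)cc1`, gives 70% in this assay.

Compound 2 stands lowest of the three numbers. Its nearest neighbour is compound 3, whose number lies higher by a margin beyond the usual scatter, and the furthest is compound 1, higher by a still larger margin. Compound 4, `CNC(=O)CCc1ccncc1-c1ccc2ccccc2c1`, has not yet been measured in this assay. It differs from compound 2 in one place: 2-(methylcarbamoyl)ethyl in place of (aminocarbamoyl)methoxy on an aromatic carbon. The new group sits on an aromatic carbon of a six-membered aromatic ring with one nitrogen, ortho to a large group and opposite the ring nitrogen, so the remaining part of the molecule is unchanged. Within the data shown here, no pair of measured compounds differs in exactly this way, so the size of this step cannot be read off directly. Compound 1 carries a related methylcarbamoyl-bearing chain and gives the highest number seen, while compound 2 with its (aminocarbamoyl)methoxy gives the lowest, which suggests an increase. For compound 4 the estimated step in this assay is a number 26 percentage points higher from compound 2 to compound 4 (beyond the scatter), a rise beyond the scatter. Compound 4 is therefore expected to give 45%, within a range from 15% to 75%.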

Compound 4, a percentage reported as inhibition, at one concentration (the size of the read-out at that concentration, not a potency): 100%
Compound 4: middle estimate off by 55 percentage points, on the low side; the measured number lies above the stated range.
By their numbers in this assay, from the lowest: compound 2; then compound 3; then compound 1; then compound 4.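

In this assay, putting 2-(methylcarbamoyl)ethyl in place of (aminocarbamoyl)methoxy on this aromatic carbon, ortho to a large group and opposite the ring nitrogen, gives a number 81 percentage points higher from compound 2 to compound 4 (beyond the scatter), so the group at this one position can by itself carry the read-out from the bottom to the top of the series. The two groups both have 6 heavy atoms and no ring, so the large step comes without any change in those counts, whereas the hydrogen-bond counts do shift, from 2 donors and 3 acceptors to 1 donor and 1 acceptor. Nothing measured here accounts for the size of this step.

The swap alters the atom attached to the aromatic carbon and the end of the chain together, so these compounds cannot show which of the two changes matters, or whether both are needed. Also open, going by these compounds, is how a carboxylic acid, an amine or a longer chain ending in a methylcarbamoyl group would fare at this carbon, and how far the single-concentration read-out reflects true differences in potency.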